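This account rests on a few compounds, and the source may have more. Where it says the series, first, only, none or still open, it means among the compounds named here.

Three dichloroacetamides have so far been tested in a functional assay on A549 cells (Homo sapiens) for cytotoxicity, read by MTT assay, with a stated time of 68 h; on this read-out higher numbers stand for weaker inhibition and lower numbers for stronger inhibition. Compound 1 `O=C(Nc1cccc(-c2cccc(F)c2)c1)C(Cl)Cl` gives 9530 nM in this assay. Compound 3 `COc1cc(F)cc(-c2cc(NC(=O)C(Cl)Cl)cc(-c3cc(F)cc(OC)c3)c2)c1`, which carries two substituted outer rings on the shared core, gives 8990 nM in this assay; this value and that of compound 1 lie within the usual scatter of each other, so the two read as alike.

Compound 2 `O=C(Nc1cccc(-c2ccc(-c3ccccc3)cc2)c1)C(Cl)Cl` stands differently. In this assay compound 2 reports only a limit, > 50000 nM, and not a number. It sits at the limit of > 50000 nM in this assay, at which 1 of the 3 values shown sits, so its place among the other values is known only as a bound.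

Compound 4 `O=C(Nc1cccc(-c2ccccc2)c1)C(Cl)Cl` has not yet been measured. It differs from compound 2 in one place: hydrogen in place of phenyl on an aromatic carbon. For the measured compounds named here, no measured pair shows this exact change, so the expected step rests on what the measured compounds show. Compound 1, which also carries a single outer ring on the shared core, gives 9530 nM, and compound 4 is expected to fall near that. The step of an at least 4.1-fold lower number from compound 2 to compound 4 (0.61 log units; beyond the scatter) is therefore expected to run toward stronger inhibition, beyond the scatter. Compound 4 is estimated at 12000 nM, with a range from 4000 nM to 40000 nM.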

Compound 4, half-maximal inhibitory concentration: 8900 nM
Compound 4: the middle estimate sits 1.3-fold (0.13 log units) above what was measured, within the range that was stated.
By their numbers in this assay, from the lowest: compounds 4, 3 and 1 (each within the scatter of the next). At a limit, above all of these: compound 2.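

In this assay, putting hydrogen in place of phenyl on this aromatic carbon, para to a large group, gives an at least 5.6-fold lower number from compound 2 to compound 4 (0.74 log units; beyond the scatter), so this change now has a measured direction, toward stronger inhibition, and a minimum size beyond the scatter. Hydrogen in place of fluoro gives a 1.1-fold lower number from compound 1 to compound 4 (0.03 log units; within the scatter), so this second change leaves the read-out within the scatter, and among these single-ring compounds it is the added phenyl, not the fluoro, that goes with a clear shift. The first step is a bound and not an exact size, and compound 2 stays a limit and not a number: the limit of > 50000 nM in this assay, at which 1 of the 4 values shown sits.

The compounds shown leave open what happens between hydrogen and phenyl at this place: a methyl group, an amine or a carboxylic acid there could read close to compound 4 or could move toward compound 2. For the compounds shown here, they also leave open whether the same change behaves alike on other cores, since this single pair is the only reading of it.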